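The source may hold more compounds than are shown below. What is called first, only, known or untested is meant among the compounds shown, and "the series" means these compounds.

Among the two compounds measured in an assay on membranes from uterus for displacement of a labelled ligand from Angiotensin type II receptor (Sus scrofa), with a stated time of 1.5 h (a higher number here means a weaker inhibitor, a lower number a stronger inhibitor), compound 2 `CCCCOC(=O)NS(=O)(=O)c1sc(CC(C)C)cc1-c1ccc(CN2CCN(C)C2=O)cc1` stands lowest, at 16.5 nM. Compound 1 `CCCCOC(=O)NS(=O)(=O)c1sc(CC(C)C)cc1-c1ccc(CN2C(=O)CN(C)C2=O)cc1`, which carries a second carbonyl in the five-membered ring, gives 68.6 nM, and the step of a 4.2-fold lower number from compound 1 to compound 2 (0.62 log units; beyond the scatter) is the only measured one. Compound 3 `CCCCOC(=O)NS(=O)(=O)c1sc(CC(C)C)cc1-c1ccc(C(=O)c2ncco2)cc1` differs from compound 2 by (1,3-oxazol-2-yl)carbonyl in place of (3-methyl-2-oxoimidazolidin-1-yl)methyl on an aromatic carbon. Among the measured compounds shown here, that measured step only altered the ring on the chain; here the whole group, chain carbon included, is exchanged, so no measured step bears directly on it. A modest step toward a higher number is expected, a 3.6-fold higher number from compound 2 to compound 3 (0.56 log units; beyond the scatter), giving compound 3 an estimated 60 nM, likely between 15 nM and 250 nM.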

Compound 3, inhibition constant: 13.8 nM
Beside the measured number, compound 3's estimate is 4.3-fold (0.64 log units) above it; the measured number lies below the stated range.
By their numbers in this assay, from the lowest: compounds 3 and 2 (each within the scatter of the next); then compound 1.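

In this assay, the whole group on this aromatic carbon, chain carbon included, can be exchanged with no change beyond the scatter (a 1.2-fold lower number from compound 2 to compound 3 (0.08 log units; within the scatter)). The (1,3-oxazol-2-yl)carbonyl group also keeps the gain over the 3-methyl-2,5-dioxoimidazolidin-1-yl compound (a 5.0-fold lower number from compound 1 to compound 3 (0.70 log units; beyond the scatter)), so a non-aromatic ring on a saturated chain carbon is not needed for a number this low. No evidence here accounts for this result.

The compounds shown do not separate the part played by the carbonyl from that of the oxazole ring. Going by these compounds, how a carboxylic acid or an amine would read on this carbon also remains open.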